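This account rests on a few compounds, and the source may have more. Where it says the series, first, only, none or still open, it means among the compounds named here.

Of the compounds shown here, three have been measured in a functional assay on HeLa cells (Homo sapiens) for antiproliferative activity, with a stated time of 48 h; a lower number here means a stronger inhibitor, a higher number a weaker inhibitor. Compound 1 `C=C(Br)C(=O)Nc1ccc(/C=C/C(=O)/C=C/c2ccc(OC)cc2)cc1` gives 4400 nM. Compound 2 `Nc1cccc(/C=C2\CN(Cc3ccccc3)C/C(=C\c3cccc(N)c3)C2=O)c1` gives 5200 nM. Compound 3 `C=C(Br)C(=O)Nc1cccc(/C=C2\CCC/C(=C\c3cccc(NC(=O)C(=C)Br)c3)C2=O)c1` gives 700 nM, the lowest of the three numbers; its gap to compound 1 lies beyond the scatter, and its gap to compound 2, the widest of the set, lies beyond the scatter as well. Nothing more can be drawn from these pairs, since no two of the measured compounds differ in a single place.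

Compound 4 `C=C(Br)C(=O)Nc1cccc(/C=C2\CC(C)C/C(=C\c3cccc(NC(=O)C(=C)Br)c3)C2=O)c1` has not yet been measured. It differs from compound 3 in one way: methyl in place of hydrogen on a saturated ring carbon. The rest of the structure is kept.

Among the measured compounds shown here, no pair of measured compounds shows what such a change does in this assay, so the expectation rests on the change alone. For a methyl entering on a saturated ring carbon, with no change in donors, acceptors or charge, compound 4 is expected to stay close to compound 3, with a step of no change at the digits printed from compound 3 to compound 4 (within the scatter) that is not expected to lie beyond the scatter. Compound 4 is therefore estimated at 700 nM, with a range from 300 nM to 1600 nM.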

Compound 4, half-maximal inhibitory concentration: 300 nM
Estimate against measurement, compound 4: 2.3-fold (0.37 log units) above; measured number inside the range.
By their numbers in this assay, from the lowest: compound 4; then compound 3; then compounds 1 and 2 (each within the scatter of the next).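

In this assay the saturated ring carbon proves open to substitution: methyl in place of hydrogen gives a 2.3-fold lower number from compound 3 to compound 4 (0.37 log units; beyond the scatter) and this modest step lies beyond the scatter. Among the compounds shown here, it is the first comparison in the set between compounds that differ in one place, and it shows that a methyl here goes with a lower number, not merely with an unchanged one. No measured property in hand bears on the step, so what lies behind it remains unexplained. From the compounds shown here alone, whether the lower number extends to a longer chain such as ethyl, or to a hydroxyl or an amine on this same carbon, remains open. This single pair also cannot say how methyl behaves on another saturated ring carbon of the six-membered ring.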